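Isopropyl in place of 1-(trifluoromethyl)ethyl: what to expect

This account rests on a few compounds, and the source may have more. Where it says the series, first, only, none or still open, it means among the compounds named here.

In a functional assay on the whole organism for inhibition, with Mus musculus as the target, with a stated time of 60 min (on this read-out lower numbers stand for an effect already at smaller amounts and higher numbers for an effect only at larger amounts of compound), three compounds sharing one core have been measured. Compound 1 `C[C@H](Oc1ccc(S(C)(=O)=O)cc1C(=O)N1Cc2ccc(C(F)(F)F)cc2C1)C(F)(F)F` gives 2 mg/kg and compound 2 `C[C@H](Oc1ccc(S(C)(=O)=O)cc1C(=O)N1Cc2ccc(-c3ccncc3)cc2C1)C(F)(F)F` gives 3 mg/kg while compound 3 `C[C@H](Oc1ccc(S(C)(=O)=O)cc1C(=O)N1Cc2ccc(C3CCOCC3)cc2C1)C(F)(F)F` gives 0.5 mg/kg as the lowest number of the three. Its gaps to both others lie beyond the scatter. Compound 4 `CC(C)Oc1ccc(S(C)(=O)=O)cc1C(=O)N1Cc2ccc(C3CCOCC3)cc2C1` has not been measured yet. It differs from compound 3 by isopropyl in place of 1-(trifluoromethyl)ethyl on an oxygen on an aromatic ring in a single change: isopropyl in place of 1-(trifluoromethyl)ethyl on an oxygen on an aromatic ring.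

Among the compounds with values here, no measured step touches this group. All three steps changed a different group, on an aromatic carbon. The step of a 1.5-fold higher number from compound 1 to compound 2 (0.18 log units; within the scatter) stayed within the scatter, whereas a 4.0-fold lower number from compound 1 to compound 3 (0.60 log units; beyond the scatter) and a 6.0-fold lower number from compound 2 to compound 3 (0.78 log units; beyond the scatter) were modest and went beyond it. These steps hint only at how far one swap can move the number in this assay and say nothing firm about direction here. Within the data shown here, compound 3 holds 0.5 mg/kg as the lowest number so far, so a modest step to a higher number is the more likely outcome, though this remains only an expectation. The estimated move is a 2.4-fold higher number from compound 3 to compound 4 (0.38 log units; beyond the scatter) and it may prove smaller. For compound 4 the estimate is 1.2 mg/kg with an expected range from 0.4 mg/kg to 4 mg/kg on this read-out.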

Compound 4, dose for 50% inhibition: 0.5 mg/kg
Estimate against measurement, compound 4: 2.4-fold (0.38 log units) above, and the stated range covers the measured number.
By their numbers in this assay, from the lowest: compounds 3 and 4 (each within the scatter of the next); then compounds 1 and 2 (each within the scatter of the next).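

In this assay, this first change at the group on the oxygen gives no change at the digits printed from compound 3 to compound 4 (within the scatter). Within the data shown here, replacing 1-(trifluoromethyl)ethyl with isopropyl removes the fluorine atoms and the defined stereocentre, yet the read-out shows no difference for this pair, so neither feature is needed to keep the number at this level when oxan-4-yl is the group on the aromatic carbon. The earlier steps varied only that aromatic carbon and could not show this, while the present step shows that a swap on the oxygen can leave the number unmoved; no information is available on what lies behind this result.

One matched pair cannot show whether the same swap would read the same way with trifluoromethyl or pyridin-4-yl on the aromatic carbon, so this finding stays tied to the oxan-4-yl series. Going by these compounds, it is also open how the number would respond to other groups on this oxygen, such as a cyclopropyl ring, a longer chain like n-butyl, or a chain carrying an amine.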